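Shortening the ether chain and adding a double bond

The source may report more compounds than this note shows. Statements on the series, on what has been measured and on what is new or still open speak of the compounds shown alone.

Compound 1 `C=CCc1cc(C(C)=O)c(O)cc1OCCCCC`: 23%
Compound 2 `C=CCc1cc(C(C)=O)c(O)cc1OCCCCCC`: 9%
Compound 3 `C=CCc1cc(C(C)=O)c(O)cc1OCCCCCCC`: 8%

In an assay on isolated protein for binding affinity to leukotriene B4 receptor 1 (Homo sapiens), tested at 1 uM (a higher number here means more inhibition at the concentration tested (going by the name of the read-out), a lower number less inhibition), compound 3 gives the lowest of the three numbers, although compound 2 sits within the scatter of it. Compound 4 `C=CCCCCOc1cc(O)c(C(C)=O)cc1CC=C` differs from compound 3 by vinyl in place of propyl on a saturated chain carbon, four bonds along the chain from an oxygen on an aromatic ring; read one bond further out, hexyl becomes pent-4-en-1-yl. The measured steps concern chain length: a number 14 percentage points lower from compound 1 to compound 2 (beyond the scatter), a number 15 percentage points lower from compound 1 to compound 3 (beyond the scatter), while a number 1 percentage points lower from compound 2 to compound 3 (within the scatter). Since compound 4 carries a chain one carbon shorter than compound 3, a modest rise back toward compound 1 is expected, tempered by the unmeasured double bond. Compound 4 is therefore expected to give 16%, between 5% and 30%, meaning an estimated step of a number 8 percentage points higher from compound 3 to compound 4 (within the scatter).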

Compound 4, a percentage reported as inhibition, at one concentration (the size of the read-out at that concentration, not a potency): 27%
The estimate for compound 4 lay 11 percentage points below the measured number; the range from low to high includes it.
By their numbers in this assay, from the lowest: compounds 3 and 2 (each within the scatter of the next); then compounds 1 and 4 (each within the scatter of the next).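

Compound 2 and compound 4 carry chains of equal length, so a number 18 percentage points higher from compound 2 to compound 4 (beyond the scatter) goes with the double bond alone, which the saturated chains could not show. Against the longer saturated chain the change also counts, with a number 19 percentage points higher from compound 3 to compound 4 (beyond the scatter), while a number 4 percentage points higher from compound 1 to compound 4 (within the scatter), so the unsaturated chain matches the shortest saturated one in this assay. Nothing measured here explains this gain. Still open, from the compounds shown here alone, is whether the double bond must sit at the chain end, and whether a triple bond or a terminal carboxylic acid would do the same.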